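The source may report more compounds than this note shows. Statements on the series, on what has been measured and on what is new or still open speak of the compounds shown alone.

Measured so far in a functional assay on SF-539 cells (Homo sapiens) for cytotoxicity, read by sulforhodamine B assay, with a stated time of 48 h; a higher number here means a weaker inhibitor of growth, a lower number a stronger inhibitor of growth:
compound 1, `ClCc1ccc(Cn2cnc3c(Cl)ncnc32)cc1`: 2340 nM
compound 2, `ClCc1cccc(Cn2cnc3c(Cl)nc(Cl)nc32)c1`: 2180 nM
compound 3, `ClCc1ccccc1Cn1cnc2ncnc(Cl)c21`: 2340 nM

Compound 2 gives the lowest of the three numbers, yet its gap to compound 1 and its gap to compound 3 both lie within the scatter, so the three compounds cannot be ordered on these data, and none of them can be called the stronger or the weaker inhibitor of growth.

Compound 4, `Nc1nc(Cl)c2ncn(Cc3cccc(CCl)c3)c2n1`, has not been measured in this assay. It differs from compound 2 in one place: amino in place of chloro on an aromatic carbon. The change sits between two ring nitrogen atoms of the shared core. Within the data shown here, no pair of measured compounds differs in one place, so no measured step shows how such a change moves this assay; what the three measured values do show is a flat series despite differing substitution on the core and on the benzyl group.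

The expectation for compound 4 is a small step from compound 2, not beyond the scatter, estimated as a 1.4-fold higher number from compound 2 to compound 4 (0.14 log units; within the scatter). For compound 4 the estimated value in this assay is 3000 nM, with a range from 1200 nM to 8000 nM.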

Compound 4, concentration for 50% growth inhibition: 4670 nM
Estimate against measurement, compound 4: 1.6-fold (0.19 log units) below; low and high end bracket the measured number.
By their numbers in this assay, from the lowest: compounds 2, 1, 3 and 4 (each within the scatter of the next, the first and the last beyond it).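

In this assay, among these compounds, amino in place of chloro on the aromatic carbon between two ring nitrogen atoms gives a 2.1-fold higher number from compound 2 to compound 4 (0.33 log units; beyond the scatter) and so provides the first readable step in a series that earlier offered no ordering. Among the compounds shown here, this position is therefore not silent: the one change examined here leaves a modest but real loss of growth inhibition rather than abolishing it. No measurement available bears on what lies behind the step.

Still open, from the compounds shown here alone, is whether the shift is specific to amino or would also follow from another replacement for chloro on this carbon, such as a methylamine, a methoxy group or a hydroxyl group. Also open, going by these compounds, is whether the same change would produce a step of similar size with the benzyl groups of compound 1 and compound 3.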